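Fluoro in place of trifluoromethyl in compound 3

The compounds below may be only part of what the source reports. "The series", "measured", "known", "first", "only" and "open" are said of these compounds alone.

In a functional assay on MCF7 cells (Homo sapiens) (a lower number here means a stronger inhibitor of growth, a higher number a weaker inhibitor of growth), compound 1 `O=S(=O)(/C=C/c1ccc(Cl)cc1Cl)Cc1ccc(Nc2ncnc3cc(Cl)ccc23)cc1` gives 25000 nM. Compound 2 `O=S(=O)(/C=C/c1ccc(C(F)(F)F)cc1F)Cc1ccc(Nc2ncnc3cc(Cl)ccc23)cc1` stands at > 100000 nM, which is a limit and not a number. Compound 3 `O=S(=O)(/C=C/c1ccc(F)cc1F)Cc1ccc(Nc2ncnc3cc(Cl)ccc23)cc1` carries fluoro in place of trifluoromethyl on an aromatic carbon, turning 2-fluoro-4-(trifluoromethyl)phenyl into 2,4-difluorophenyl (fluoro in place of trifluoromethyl on an aromatic carbon). For the measured compounds named here, the only measured step bearing on this is an at least 4.0-fold higher number from compound 1 to compound 2 (0.60 log units; beyond the scatter), which replaced 2,4-dichlorophenyl with 2-fluoro-4-(trifluoromethyl)phenyl. Reversing the trifluoromethyl part of that step is expected to lower the number, giving an estimated at least 2.5-fold lower number from compound 2 to compound 3 (0.39 log units; beyond the scatter). For compound 3 the estimated value is 40000 nM, with an expected range of 10000 nM to 100000 nM.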

Compound 3, concentration for 50% growth inhibition: > 100000 nM
Compound 3: only a limit was reported (the forecaster's own chance of this, stated with the estimate: 30%); middle value at least 2.5-fold (0.39 log units) from the limit.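

In this assay compound 3 gives > 100000 nM, which is a limit and not a number. Trifluoromethyl is therefore not required for the weak growth inhibition at this position, since 2,4-difluorophenyl in place of 2,4-dichlorophenyl also gives an at least 4.0-fold higher number from compound 1 to compound 3 (0.60 log units; beyond the scatter). The step between compound 2 and compound 3 cannot be read, because both stop at the same ceiling: the limit of > 100000 nM in this assay, at which 2 of the 3 values shown sit.

From the compounds shown here alone, how compound 2 and compound 3 rank remains open. So does whether a chloro, a methoxy or an amine at this position, with the fluoro group kept, would bring the value back under the limit.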